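The source may report more compounds than this note shows. Statements on the series, on what has been measured and on what is new or still open speak of the compounds shown alone.

In a functional assay on NIH3T3 cells (Mus musculus) (on this read-out higher numbers stand for an effect only at larger amounts of compound and lower numbers for an effect already at smaller amounts), three compounds sharing one core have been measured. Compound 2 `Cn1cncc1C(OCc1ccc(C#N)cc1/C=C/c1ccc([N+](=O)[O-])cc1)c1ccc(C#N)cc1`, which carries 2-(4-nitrophenyl)ethenyl, gives 2.24 nM. Compound 3 `Cn1cncc1C(OCc1ccc(C#N)cc1C#Cc1ccccc1)c1ccc(C#N)cc1`, which carries 2-phenylethynyl, gives 0.1 nM, the lower of the two actual numbers. Compound 1 `Cn1cncc1C(OCc1ccc(C#N)cc1C#Cc1ccccn1)c1ccc(C#N)cc1`, which carries 2-(pyridin-2-yl)ethynyl, is reported only as a limit, > 0.1 nM. On these data alone, two steps therefore stay open in size: a step that the limit leaves unreadable from compound 1 to compound 2 and a number no higher from compound 1 to compound 3 (the limit leaves the size open). Within the data shown here, the one readable step is a 22-fold lower number from compound 2 to compound 3 (1.35 log units; beyond the scatter), and it is large.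

Compound 4 `Cn1cncc1C(OCc1ccc(C#N)cc1CCC(C)(C)C)c1ccc(C#N)cc1` differs from compound 3 at that same place: 3,3-dimethylbutyl in place of 2-phenylethynyl on an aromatic carbon. The triple bond and the aromatic ring leave, and the 3,3-dimethylbutyl group that enters has no ring. Among the measured compounds shown here, no measured compound has a group without a ring here, so the step rests on thin ground. The readable step, a 22-fold lower number from compound 2 to compound 3 (1.35 log units; beyond the scatter), shows that the number can move well beyond the scatter when this group changes. For the measured compounds named here, compound 3, at 0.1 nM, holds the lowest number so far, so a move upward is expected in this assay. The expected step is an 8.0-fold higher number from compound 3 to compound 4 (0.90 log units; beyond the scatter). For compound 4 the estimated value is 0.8 nM, with an expected range of 0.15 nM to 5 nM.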

Compound 4, half-maximal effective concentration: 0.54 nM
The estimate for compound 4 lay 1.5-fold (0.17 log units) above the measured number, within the range that was stated.
By their numbers in this assay, from the lowest: compound 3; then compound 4; then compound 2.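

In this assay an aromatic ring at this place is not required for a low number: 3,3-dimethylbutyl, which has no ring and no triple bond, gives a 5.4-fold higher number from compound 3 to compound 4 (0.73 log units; beyond the scatter) and also a 4.1-fold lower number from compound 2 to compound 4 (0.62 log units; beyond the scatter) in the same series. An aromatic ring in this group therefore does not set the number by itself, since compound 2, with its ring, stands higher than compound 4, while compound 3, with its ring, stands lower. The steps that involve compound 1 cannot be read because its entry is a limit and not a number: the limit of > 0.1 nM in this assay, at which 1 of the 4 values shown sits.

Whether the lower number of compound 3 goes with its triple bond or with its ring stays open, as no compound shown has the triple bond without a ring. On these data alone, how the number would move with a longer chain than 3,3-dimethylbutyl, or with an amine or a carboxylic acid at the end of such a chain, also stays open.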